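Swapping a Cyclobutyl Ring for an Oxetane

The source may hold more compounds than are shown below. What is called first, only, known or untested is meant among the compounds shown, and "the series" means these compounds.

Of the compounds shown here, two sharing one core have been measured in an assay on cells for activation of Guanylate cyclase soluble subunit alpha-1 (Rattus norvegicus), read by cGMP accumulation and immunoassay, with a stated time of 10 min; on this read-out lower numbers stand for an effect already at smaller amounts and higher numbers for an effect only at larger amounts of compound. Compound 1 `COC(=O)N(CCO)c1c(N)nc(-c2nn(Cc3ccccc3F)c3ncccc23)nc1N` gives 0.3 uM in this assay. Compound 2 `Nc1nc(-c2nn(Cc3ccccc3F)c3ncccc23)nc(N)c1NC(=O)OC1CCC1`, in which the group on the aromatic carbon is altered, gives 0.2 uM. For the measured compounds named here, the only measured step, a 1.5-fold lower number from compound 1 to compound 2 (0.18 log units; within the scatter), therefore shows no real difference between them. Going by the values given here, compound 2 holds the smaller of the two numbers measured so far, with compound 1 as its only neighbour and the gap between them inside the scatter.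

The next compound, compound 3 `Nc1nc(-c2nn(Cc3ccccc3F)c3ncccc23)nc(N)c1NC(=O)OC1COC1`, keeps everything of compound 2 except one change: oxetan-3-yl in place of cyclobutyl on an oxygen next to a carbonyl group. Among the compounds with values here, no measured step touches a swap of one four-membered ring for another at this position; the step from compound 1 to compound 2 changed a different part of the same carbamate and stayed within the scatter. With nothing in the data pointing to a shift in either direction, compound 3 is expected to read close to compound 2, as an estimated step of a 1.5-fold higher number from compound 2 to compound 3 (0.18 log units; within the scatter). The estimate for compound 3 in this assay is 0.3 uM, with a range from 0.1 uM to 0.9 uM.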

Compound 3, minimum effective concentration: 2.3 uM
Estimate against measurement, compound 3: 7.7-fold (0.88 log units) below; the measured number lies above the stated range.
By their numbers in this assay, from the lowest: compounds 2 and 1 (each within the scatter of the next); then compound 3.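

This position is not indifferent to the ring on the oxygen next to the carbonyl group. In this assay, oxetan-3-yl in place of cyclobutyl keeps the same number of heavy atoms and exchanges one ring carbon for an oxygen, yet it gives a 12-fold higher number from compound 2 to compound 3 (1.06 log units; beyond the scatter) and so a large step from a small edit. The other comparison reads a 7.7-fold higher number from compound 1 to compound 3 (0.88 log units; beyond the scatter) and points the same way, so compound 3 stands apart from compound 1 and compound 2, which remain within the scatter of each other, and this single ring atom counts for more here than the whole difference between the groups of those two compounds. Nothing available bears on why the ring oxygen has this effect.

The compounds shown leave open whether the higher number belongs to the oxygen in the ring specifically or would also appear with other groups at this place, such as a cyclopentyl ring, an azetidine ring with its amine nitrogen, or an open isopropyl chain. They also leave open whether the 2-hydroxyethyl group carried by compound 1 would alter the reading of an oxetan-3-yl carbamate.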